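Meta-hydroxyphenyl replacing para-hydroxyphenyl in the phenyl series

The source may report more compounds than this note shows. Statements on the series, on what has been measured and on what is new or still open speak of the compounds shown alone.

Compound 1 `Oc1cccc(-c2cc(-c3cccnc3)nc(-c3cccc(Cl)c3)c2)c1` and compound 2 `Oc1cccc(-c2cc(-c3ccsc3)nc(-c3cccc(Cl)c3)c2)c1` both carry a 3-hydroxyphenyl group; in an assay on isolated protein for inhibition of DNA topoisomerase 1 (Homo sapiens), with a stated time of 30 min, tested at 100 uM (on this read-out higher numbers stand for a stronger effect at the one concentration tested and lower numbers for a weaker effect), compound 1 gives 27.6% and compound 2 gives 26.2%. Going by the values given here, the only measured step in the set, a number 1.4 percentage points lower from compound 1 to compound 2 (within the scatter), shows that exchanging the other aryl group leaves the read-out essentially unchanged. Compound 3 `Oc1ccc(-c2cc(-c3ccccc3)nc(-c3cccc(Cl)c3)c2)cc1` carries a 4-hydroxyphenyl group in place of the 3-hydroxyphenyl and gives 0% in this assay, the lowest of the three numbers, far beyond the scatter from both compound 1 and compound 2.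

Compound 4 `Oc1cccc(-c2cc(-c3ccccc3)nc(-c3cccc(Cl)c3)c2)c1` returns to the arrangement of compound 1 and compound 2 at the hydroxyphenyl position: 3-hydroxyphenyl in place of 4-hydroxyphenyl on an aromatic carbon, on an aromatic carbon of a six-membered aromatic ring with 1 nitrogen, opposite the ring nitrogen. Among the compounds with values here, no measured step isolates this change, and the phenyl partner of compound 4 is itself unmeasured in the 3-hydroxyphenyl arrangement. Given that compound 1 gives 27.6% and compound 2 gives 26.2% with the same 3-hydroxyphenyl group, a rise is expected for compound 4 in this assay, though the size is uncertain; the expected step is a number 20 percentage points higher from compound 3 to compound 4 (beyond the scatter). Compound 4 is therefore estimated at 20%, within 0% to 35%.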

Compound 4, a percentage reported as inhibition, at one concentration (the size of the read-out at that concentration, not a potency): 11.5%
Compound 4: the middle estimate sits 8.5 percentage points above what was measured; the range from low to high includes it.
By their numbers in this assay, from the lowest: compound 3; then compound 4; then compounds 2 and 1 (each within the scatter of the next).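

Within this assay the swap of 4-hydroxyphenyl for 3-hydroxyphenyl opposite the ring nitrogen, with the phenyl partner unchanged, gives a number 11.5 percentage points higher from compound 3 to compound 4 (beyond the scatter) as the first direct reading of this change. The other aryl group also counts once 3-hydroxyphenyl is held: the two new partner steps are a number 14.7 percentage points lower from compound 2 to compound 4 (beyond the scatter) and a number 16.1 percentage points lower from compound 1 to compound 4 (beyond the scatter) so phenyl stands apart from thiophen-3-yl and pyridin-3-yl, a difference the earlier pair of partners, which read alike, could not reveal. No supporting data bear on why either kind of step arises.

Open, as far as these compounds go, is whether an amine or a methoxy group at this place would read like the hydroxyl. Also open, from the compounds shown here alone, is whether the gap between 3-hydroxyphenyl and 4-hydroxyphenyl keeps its size with thiophen-3-yl or pyridin-3-yl as the partner.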